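From 3,4-dimethoxyphenoxy to 3,4-dihydroxyphenoxy in compound 2

A few compounds are considered here, and "the series" means these few. Any claim that something is new, unique, unknown or untested is made for them only; others in the source may bear on it.

Of the compounds shown here, three have been measured so far in a functional assay on RS4-11 cells (Homo sapiens) for inhibition, read by CCK-8 assay, with a stated time of 48 h; a higher number here means a weaker inhibitor, a lower number a stronger inhibitor. Compound 1 (`COc1ccc(Oc2ccc(C(C)C)cc2-c2ccsc2S(=O)(=O)NCCNC(=S)Nc2ccc([N+](=O)[O-])cc2)cc1OC`) gives 5800 nM, compound 2 (`COc1ccc(Oc2ccc(C(C)C)cc2-c2ccsc2S(=O)(=O)NCCNC(=O)Nc2cc(Cl)cc(Cl)c2)cc1OC`) gives 9000 nM and compound 3 (`Cc1ccc(-c2ccsc2S(=O)(=O)NCCNC(=S)Nc2ccc([N+](=O)[O-])cc2)c(Oc2ccc(O)c(O)c2)c1`) gives 5100 nM. Compound 2 therefore stands within the usual scatter of both others, and the three numbers cannot be ranked.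

Compound 4 (`CC(C)c1ccc(Oc2ccc(O)c(O)c2)c(-c2ccsc2S(=O)(=O)NCCNC(=O)Nc2cc(Cl)cc(Cl)c2)c1`) keeps all of compound 2 except one group: 3,4-dihydroxyphenyl in place of 3,4-dimethoxyphenyl on an oxygen on an aromatic ring. Put simply, 3,4-dihydroxyphenyl stands in place of 3,4-dimethoxyphenyl on an oxygen on an aromatic ring.

Among the measured compounds shown here, no measured step makes this exact swap. For the measured compounds named here, the only single-change step, a 1.6-fold higher number from compound 1 to compound 2 (0.19 log units; within the scatter), lies within the scatter, but it concerns the group on an amine nitrogen, so it shows only how little that other change moved the number. The closest hint comes from compound 3, which carries 3,4-dihydroxyphenoxy and gives 5100 nM, while compound 1, which carries 3,4-dimethoxyphenoxy, gives 5800 nM. These two values lie within the scatter of each other, although the two compounds also differ elsewhere.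

The expected step, a 1.4-fold lower number from compound 2 to compound 4 (0.14 log units; within the scatter), is therefore none beyond the scatter. For compound 4 the estimated value is 6500 nM, with an expected range from 2800 nM to 15000 nM.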

Compound 4, half-maximal inhibitory concentration: 6400 nM
Compound 4: middle estimate off by 1.0-fold (0.01 log units), on the high side; the measured number falls inside the stated range.
By their numbers in this assay, from the lowest: compounds 3, 1, 4 and 2 (each within the scatter of the next).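

In this assay, among the compounds shown here, placing 3,4-dihydroxyphenoxy where compound 2 carries 3,4-dimethoxyphenoxy gives a 1.4-fold lower number from compound 2 to compound 4 (0.15 log units; within the scatter) and so provides the first direct reading of this swap, with the rest of the molecule held constant. For the compounds shown here, until now, the only hint came from compound 1 and compound 3, which differ in other places as well. This single-change pair shows that the numbers cannot be told apart when the dimethoxy group gives way to a dihydroxy group with its hydrogen-bond donors, although no measurement at hand offers an explanation for this result.

Going by these compounds alone, the four compounds, each within the scatter of the next, do not yet identify any change that clearly moves the number, so this pair shows only that one swap at this position cannot be distinguished. Still open, from the compounds shown here alone, is whether a phenyl ring carrying a single hydroxyl, an amine or a carboxylic acid on this oxygen would give a step beyond the scatter, and whether the same swap would read alike on a compound with a thiourea in place of the urea.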